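The compounds below may be only part of what the source reports. "The series", "measured", "known", "first", "only" and "open" are said of these compounds alone.

Measured so far in a functional assay on CHO cells for antagonist activity at sphingosine 1-phosphate receptor 2 (Homo sapiens), read by calcium flux; on this read-out lower numbers stand for stronger inhibition and higher numbers for weaker inhibition: compound 1 `O=C(Cc1nn(CC(=O)N2CCOCC2)c(=O)c2ccccc12)Nc1ccc(OC(F)(F)F)c(Cl)c1` gives 30 nM; compound 2 `COC(C(=O)O)c1nn(Cc2cn3cc(OCC4CC4)c(Cl)cc3n2)c2ccccc2c1=O` gives 23 nM; compound 3 `C[C@H](C(=O)O)n1nc(Cn2cc3cc(OCC4CC4)c(Cl)cc3n2)c2ccccc2c1=O` gives 3.2 nM.

Compound 1 stands at the highest of the three numbers. The gap to compound 2 lies within the scatter, so the two are read as alike; the gap to compound 3 lies beyond the scatter, compound 3 giving the lower number. Compound 4 `O=C(Cc1nn(C2CC2)c(=O)c2ccccc12)Nc1ccc(OC(F)(F)F)c(Cl)c1` differs from compound 1 in one place: cyclopropyl in place of ((morpholin-4-yl)carbonyl)methyl on an aromatic nitrogen. Within the data shown here, no measured pair shows the effect of this exchange on the aromatic nitrogen, and compound 2 and compound 3 share neither the amide side of compound 1 nor its substituent there. The step of a 1.3-fold higher number from compound 1 to compound 4 (0.12 log units; within the scatter) is therefore expected to stay within the scatter, with no clear direction. For compound 4 the estimate is 40 nM, with a range of 12 nM to 130 nM.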

Compound 4, half-maximal inhibitory concentration: 218 nM
Beside the measured number, compound 4's estimate is 5.5-fold (0.74 log units) below it, and the stated range ends below it.
By their numbers in this assay, from the lowest: compound 3; then compounds 2 and 1 (each within the scatter of the next); then compound 4.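

In this assay, among these compounds, the exchange of ((morpholin-4-yl)carbonyl)methyl for cyclopropyl on the aromatic nitrogen gives a 7.3-fold higher number from compound 1 to compound 4 (0.86 log units; beyond the scatter) and is the first one-place comparison. The read-out therefore responds to the group on this nitrogen, and with the amide side held constant the larger morpholine-bearing group goes with the lower number. Nothing at hand explains this step.

Which part of the departing group matters, the morpholine ring or the carbonyl, stays open. A plain methyl or a dimethylamide on this nitrogen would separate the two.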